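Methyl for Cyclopropyl on a Ring Amine Nitrogen

A few compounds are considered here, and "the series" means these few. Any claim that something is new, unique, unknown or untested is made for them only; others in the source may bear on it.

Measured compounds:
compound 1 `CN(C[C@H]1Cc2c(cccc2N2CCN(C3CC3)CC2)CN1)[C@H]1CCCc2cccnc21` gives > 30000 nM
compound 2 `c1cnc2c(c1)CCC[C@@H]2N(CC1CCCCC1)C[C@H]1Cc2c(cccc2N2CCNCC2)CN1` gives > 30000 nM

In a functional assay on CCRF-CEM cells for agonist activity at C-X-C chemokine receptor type 4 (Homo sapiens), read by calcium flux, with a stated time of 25 min (on this read-out higher numbers stand for an effect only at larger amounts of compound and lower numbers for an effect already at smaller amounts), compound 1 gives > 30000 nM, which is a limit of the assay and not a number. Compound 2 likewise gives > 30000 nM in this assay, again a limit rather than a number. Compound 1 therefore stands at the limit of > 30000 nM in this assay, at which 2 of the 2 values shown sit, with no numeric value to place it against compound 2.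

Compound 3 `CN1CCN(c2cccc3c2C[C@H](CN(C)[C@H]2CCCc4cccnc42)NC3)CC1` has not yet been measured in this assay. It differs from compound 1 by methyl in place of cyclopropyl on an amine nitrogen in a ring, a change cut one bond further out reading 4-cyclopropylpiperazin-1-yl to 4-methylpiperazin-1-yl. Since compound 1 sits at the limit of > 30000 nM in this assay, at which 2 of the 2 values shown sit, the step from compound 1 to compound 3 is expected to be a step that the limit leaves unreadable from compound 1 to compound 3, that is, no step beyond the scatter that would bring compound 3 into the measurable range. Compound 3 is accordingly expected to give 40000 nM in this assay, within 10000 nM to 150000 nM, most likely reported again as a limit.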

Compound 3, half-maximal effective concentration: > 30000 nM
Compound 3 ended at the assay's limit (the forecaster's own chance of this, stated with the estimate: 85%); the middle value lies beyond the limit too.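

Compound 1 and compound 3 both end at a limit of the assay and not at a number, so no step between them can be read: the limit of > 30000 nM in this assay, at which 3 of the 3 values shown sit.

The compounds shown leave open whether methyl in place of cyclopropyl changes anything in this assay, as none of them gives a numeric value.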